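The compounds below may be only part of what the source reports. "The series", "measured", "known", "first", "only" and "open" are said of these compounds alone.

In a functional assay on HCT-116 cells (Homo sapiens) for inhibition, read by sulforhodamine B assay, with a stated time of 2 days (on this read-out lower numbers stand for stronger inhibition of growth and higher numbers for weaker inhibition of growth), compound 1 `CC1=C(C(=O)Nc2cccc([N+](=O)[O-])c2)C(c2ccc(O)cc2O)NC(SCc2ccccc2)=N1` gives 29000 nM. Compound 2 `CC1=C(C(=O)Nc2cccc([N+](=O)[O-])c2)C(c2ccc(O)cc2O)NC(NCc2ccccc2)=N1` is reported in this assay only as the limit > 100000 nM, not as a number. The step of an at least 3.4-fold higher number from compound 1 to compound 2 (0.53 log units; beyond the scatter) therefore rests on (the limit of > 100000 nM in this assay, at which 1 of the 2 values shown sits). Compound 3 `CC1=C(C(=O)Nc2cccc([N+](=O)[O-])c2)C(c2ccc(O)cc2O)NC(Nc2ccc([N+](=O)[O-])cc2Cl)=N1` carries 2-chloro-4-nitrophenyl in place of benzyl on an amine nitrogen. For the measured compounds named here, no measured step covers an aryl group entering on that amine nitrogen; the single measured step concerns benzylamino in place of benzylsulfanyl, so it gives no direction here. With compound 2 sitting at the limit, compound 3 is expected to stay near it, a step of a number no higher from compound 2 to compound 3 (the limit leaves the size open). The estimate for compound 3 in this assay is 100000 nM, with a range of 40000 nM to 300000 nM.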

Compound 3, concentration for 50% growth inhibition: 10900 nM
Estimate against measurement, compound 3: 9.2-fold (0.96 log units) above, outside the stated range (below it).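

In this assay, an aryl group on the amine nitrogen lifts the series off the limit seen with benzyl: 2-chloro-4-nitrophenyl in place of benzyl gives an at least 9.1-fold lower number from compound 2 to compound 3 (0.96 log units; beyond the scatter). An amine nitrogen at this place is therefore compatible with growth inhibition, and (2-chloro-4-nitrophenyl)amino in place of benzylsulfanyl gives a 2.7-fold lower number from compound 1 to compound 3 (0.42 log units; beyond the scatter). The size of the first step stays open, as compound 2 is held only as a limit: the limit of > 100000 nM in this assay, at which 1 of the 3 values shown sits.

Open, as far as these compounds go, is whether the chlorine, the nitro group or the directly attached aryl ring carries the change. Also open, from the compounds shown here alone, is how an unsubstituted phenyl or a longer chain such as phenylethyl on that amine nitrogen would read.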